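The source may hold more compounds than are shown below. What is called first, only, known or untested is meant among the compounds shown, and "the series" means these compounds.

Compound 1 `c1ccc(CCc2ccccc2-c2c[nH]nn2)cc1`: 90%
Compound 2 `c1ccc(-c2c[nH]nn2)c(CCC2CCCC2)c1`: 89%

In an assay on cells for inhibition of Indoleamine 2,3-dioxygenase 2 (Mus musculus), with a stated time of 24 h, tested at 200 uM (a higher number here means more inhibition at the concentration tested (going by the name of the read-out), a lower number less inhibition), compound 1 gives 90% and compound 2 gives 89%. Of these two numbers compound 2 holds the lower one, yet the step of a number 1 percentage points lower from compound 1 to compound 2 (within the scatter) lies within the scatter, so the two compounds cannot be separated on this read-out. Compound 3 `c1ccc(-c2c[nH]nn2)c(CCC2CCCCC2)c1` differs from compound 2 by cyclohexyl in place of cyclopentyl on a saturated chain carbon, two bonds along the chain from an aromatic carbon. Among the compounds with values here, the only measured step that bears on this is a number 1 percentage points lower from compound 1 to compound 2 (within the scatter), where one ring was exchanged for another at the same saturated chain carbon and the read-out hardly moved. The present exchange of cyclohexyl for cyclopentyl at that same place is a closely related change, so the step of no change at the digits printed from compound 2 to compound 3 (within the scatter) is expected to stay within the scatter. Compound 3 is therefore estimated at 89%, with a range from 78% to 97%.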

Compound 3, a percentage reported as inhibition, at one concentration (the size of the read-out at that concentration, not a potency): 95%
Beside the measured number, compound 3's estimate is 6 percentage points below it, within the range that was stated.
By their numbers in this assay, from the lowest: compounds 2, 1 and 3 (each within the scatter of the next).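

Going from cyclopentyl to cyclohexyl on a saturated chain carbon, two bonds along the chain from an aromatic carbon, gives in this assay a number 6 percentage points higher from compound 2 to compound 3 (within the scatter), so the added ring carbon does not separate these compounds. The direct exchange of phenyl for cyclohexyl at that place gives a number 5 percentage points higher from compound 1 to compound 3 (within the scatter), which means that an aromatic ring and non-aromatic carbon rings of two sizes cannot be told apart here on this read-out. No other kind of measurement accompanies these numbers to help interpret them.

Each number is a reading at one concentration rather than a potency, so any differences in potency among these compounds remain open. All three end groups are carbon-only rings, which leaves open how an amine or a carboxylic acid at that place, or a longer chain, would read.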